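Replacing a trichlorophenyl group in a growth inhibitor

A few compounds are considered here, and "the series" means these few. Any claim that something is new, unique, unknown or untested is made for them only; others in the source may bear on it.

In a functional assay on DU-145 cells (Homo sapiens) for inhibition, read by trypan blue exclusion, with a stated time of 96 h (a lower number here means a stronger inhibitor of growth, a higher number a weaker inhibitor of growth), compound 1 (`O=C(/C(=C\c1cc(Cl)cc(Cl)c1Cl)S(=O)(=O)Cc1ccc(Cl)cc1)c1ccc(Br)cc1`) gives 1000 nM. Among the compounds with values here, compound 2 (`O=C(/C(=C\c1ccc(I)cc1)S(=O)(=O)c1ccc(Br)cc1)c1ccc(Br)cc1`) gives 1000 nM, level with compound 1, and these two share the lowest number so far. Compound 3 (`Cc1ccc(CS/C(=C/c2cc(Cl)cc(Cl)c2)C(=O)c2ccc(Cl)cc2)cc1`) stands apart at 10000 nM. Its gap to compound 1 lies beyond the scatter.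

Compound 4 (`COc1ccc(/C=C(\C(=O)c2ccc(Br)cc2)S(=O)(=O)Cc2ccc(Cl)cc2)c(O)c1`) carries 2-hydroxy-4-methoxyphenyl in place of 2,3,5-trichlorophenyl on a double-bonded chain carbon bound to a double-bonded chain carbon. Within the data shown here, no measured pair shows a change at this place, so the guide is thin. Compound 2, which lacks the trichlorophenyl group, still gives 1000 nM, so no shift beyond the scatter in either direction is expected in this assay, and the expected step is no change at the digits printed from compound 1 to compound 4 (within the scatter). For compound 4 the estimated value is 1000 nM, with an expected range from 200 nM to 5000 nM.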

Compound 4, concentration for 50% growth inhibition: 10000 nM
Compound 4: the middle estimate sits 10-fold (1.00 log units) below what was measured; measured number outside the range, above it.
By their numbers in this assay, from the lowest: compounds 1 and 2 (each within the scatter of the next); then compounds 3 and 4 (each within the scatter of the next).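

Within the data shown here, this is the first step read at this place: in this assay, 2-hydroxy-4-methoxyphenyl in place of 2,3,5-trichlorophenyl gives a 10-fold higher number from compound 1 to compound 4 (1.00 log units; beyond the scatter). So the group on this chain carbon matters for growth inhibition, and swapping one for the other is not neutral, even though both are six-membered aromatic rings of the same heavy-atom count. Nothing measured here explains the step.

From the compounds shown here alone, the swap removes the chlorines and adds hydroxy and methoxy at once, so which of these changes counts stays open. Going by these compounds, whether an amine or a carboxylic acid on this ring would keep the growth inhibition also remains open.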